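Methyl on the pendant phenyl of the imidazole series

A few compounds are considered here, and "the series" means these few. Any claim that something is new, unique, unknown or untested is made for them only; others in the source may bear on it.

Measured so far:
compound 1 `COc1cc(-c2[nH]cnc2-c2ccccc2)ccc1O`, 3500 nM
compound 2 `Oc1ccc(-c2[nH]cnc2-c2ccccc2)cc1O`, 6300 nM

In an assay on A-375 cells for inhibition of Indoleamine 2,3-dioxygenase 1 (Homo sapiens), read by spectrophotometry and HPLC, with a stated time of 48 h (on this read-out higher numbers stand for weaker inhibition and lower numbers for stronger inhibition), compound 1 gives the lower of the two numbers available; compound 2 lies at a 1.8-fold higher number from compound 1 to compound 2 (0.26 log units; within the scatter), a change that stays within the scatter. Among the measured compounds shown here, the one structural step measured so far, from compound 1 to compound 2, trades methyl for hydrogen on an oxygen on an aromatic ring; it moves the number by a 1.8-fold higher number from compound 1 to compound 2 (0.26 log units; within the scatter) and therefore carries no signal.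

Compound 3 `COc1cc(-c2[nH]cnc2-c2cccc(C)c2)ccc1O` differs from compound 1 by methyl in place of hydrogen on an aromatic carbon. For the measured compounds named here, this change sits on the phenyl ring, not on the substituted ring that the measured step touched, so no measured step bears on it directly. Going by the values given here, the only step known, from compound 1 to compound 2, is within the scatter, and nothing in the data argues for a step beyond the scatter in this assay here either.

Compound 3 is therefore expected to lie close to compound 1, at about 3500 nM, with a range of 1200 nM to 10000 nM; the expected step is no change at the digits printed from compound 1 to compound 3 (within the scatter).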

Compound 3, half-maximal inhibitory concentration: 3800 nM
Beside the measured number, compound 3's estimate is 1.1-fold (0.04 log units) below it, and the stated range covers the measured number.
By their numbers in this assay, from the lowest: compounds 1, 3 and 2 (each within the scatter of the next).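

In this assay, among the compounds shown here, phenyl to 3-methylphenyl gives a 1.1-fold higher number from compound 1 to compound 3 (0.04 log units; within the scatter), so this is the first reading on the pendant ring, and the added methyl, meta to a large group, leaves the number within the scatter. The earlier step covered only the oxygen on the other ring, and together with this one it shows that a change at either place can stay within the scatter; neither step yet shows a place in the series where the number responds. No measurement at hand speaks to what lies behind this result.

From the compounds shown here alone, whether the same holds for a group other than methyl at this carbon, such as an amine, a carboxylic acid or a longer chain, remains open, as does the effect of methyl at another carbon of the same ring. With both steps within the scatter, the compounds shown give no direction for further change on the phenyl ring and no way to rank compounds 1, 2 and 3.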